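Nitro to Trifluoromethyl Swap Repeated on a Second Core

This account rests on a few compounds, and the source may have more. Where it says the series, first, only, none or still open, it means among the compounds named here.

Measured in a functional assay on HepG2 cells (Homo sapiens) for inhibition, read by MTT assay, with a stated time of 72 h; on this read-out lower numbers stand for stronger inhibition and higher numbers for weaker inhibition:
compound 1, `COc1cc(O)c(CC=C(C)C)c(O)c1C(=O)/C=C/c1ccc([N+](=O)[O-])cc1`, gives 12400 nM
compound 2, `COc1cc(O)c(CC=C(C)C)c(O)c1C(=O)/C=C/c1ccc(C(F)(F)F)cc1`, gives 6500 nM
compound 3, `COc1cc(OC)c(C(=O)/C=C/c2ccc([N+](=O)[O-])cc2)c(OC)c1`, gives 9400 nM

Compound 1 and compound 2 share one core and differ in a single place: trifluoromethyl in place of nitro on an aromatic carbon. This change gave a 1.9-fold lower number from compound 1 to compound 2 (0.28 log units; within the scatter). Compound 3 carries a different core; how the core of compound 3 differs from the core of compound 1 is not broken down here. The values of compound 3 and compound 1 lie within the scatter of each other, as do those of compound 3 and compound 2, so no order among the three is claimed.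

Compound 4, `COc1cc(OC)c(C(=O)/C=C/c2ccc(C(F)(F)F)cc2)c(OC)c1`, is not yet measured. It stands to compound 3 as compound 2 stands to compound 1: trifluoromethyl in place of nitro on an aromatic carbon. The place described for this change is the same, word for word, as for the change from compound 1 to compound 2, so the two are the same change made on two cores. Among the compounds with values here, with only one earlier instance, and that instance within the scatter, the expectation for compound 4 rests on a single step. In this assay, within the data shown here, compound 4 is expected to show a 1.7-fold lower number from compound 3 to compound 4 (0.23 log units; within the scatter) because a 1.9-fold lower number from compound 1 to compound 2 (0.28 log units; within the scatter) is the only earlier instance of this change and the only guide available. The estimate for compound 4 is 5500 nM, with a likely range from 2500 nM to 12000 nM.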

Compound 4, half-maximal inhibitory concentration: 9700 nM
Estimate against measurement, compound 4: 1.8-fold (0.25 log units) below; measured number inside the range.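

In this assay, putting trifluoromethyl in place of nitro on the second core gave a 1.0-fold higher number from compound 3 to compound 4 (0.01 log units; within the scatter), so this step, like the earlier one on the core of compound 1, lies within the scatter. Set side by side, the two steps cannot be told apart: the same change on two cores in this assay, a 1.9-fold lower number (0.28 log units; within the scatter) from compound 1 to compound 2 and a 1.0-fold higher number (0.01 log units; within the scatter) from compound 3 to compound 4, 2.0-fold (0.29 log units) apart, within the scatter of two such steps. Within the data shown here, this shows that, on these two cores, the change gave no step that stands clear of the scatter and no difference between the cores that does so, but it does not show that the change has any effect on either core, that the two cores respond alike to it, or that the same would hold on any further core.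

The compounds shown leave open whether a different group on the same aromatic carbon, such as an amine, a carboxylic acid or a nitrile, would give a step beyond the scatter on either core. They also leave open whether the two cores would part ways under such a group, a question that the nitro and trifluoromethyl pairs cannot answer.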